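Notes on the chain substituent: compound 3 to compound 4

The source may report more compounds than this note shows. Statements on the series, on what has been measured and on what is new or still open speak of the compounds shown alone.

Compound 3 `CNCC(=O)NC[C@@H]1CCCc2cc(S(=O)(=O)c3cccc(F)c3)ccc21` stands second highest of the three numbers in an assay on isolated protein for displacement of a labelled ligand from 5-hydroxytryptamine receptor 6 (Homo sapiens) (on this read-out lower numbers stand for stronger inhibition and higher numbers for weaker inhibition), where compound 3 gives 0.159 nM. Nearest is compound 2 `O=S(=O)(c1cccc(F)c1)c1ccc2c(c1)CCC[C@H]2CN1CC(O)C1`, for which compound 2 gives 0.1 nM, a gap within the scatter; furthest is compound 1 `O=C(NC[C@@H]1CCCc2cc(S(=O)(=O)c3cccc(F)c3)ccc21)c1ncc[nH]1`, for which compound 1 gives 15.9 nM. Compound 4 `CC(=O)N(C)C[C@@H]1CCCc2cc(S(=O)(=O)c3cccc(F)c3)ccc21` carries acetyl(methyl)amino in place of (((methylamino)methyl)carbonyl)amino on a saturated chain carbon bound to a saturated ring carbon. For the measured compounds named here, no measured step removes this piece outright. The step of a 100-fold lower number from compound 1 to compound 3 (2.00 log units; beyond the scatter) shows the weight of (methylamino)methyl entering on the carbonyl carbon; a 160-fold lower number from compound 1 to compound 2 (2.20 log units; beyond the scatter) is of like size, while a 1.6-fold higher number from compound 2 to compound 3 (0.20 log units; within the scatter) lies within the scatter. With (methylamino)methyl and the hydrogen-bond donors gone, the number for compound 4 is expected to rise, a 190-fold higher number from compound 3 to compound 4 (2.28 log units; beyond the scatter). Compound 4 is estimated at 30 nM, range 5 nM to 200 nM.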

Compound 4, inhibition constant: 1.59 nM
Estimate against measurement, compound 4: 19-fold (1.28 log units) above, and the stated range ends above it.
By their numbers in this assay, from the lowest: compounds 2 and 3 (each within the scatter of the next); then compound 4; then compound 1.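

In this assay, the step of a 10-fold higher number from compound 3 to compound 4 (1.00 log units; beyond the scatter) shows that this position tolerates acetyl(methyl)amino, with 0 hydrogen-bond donors, at a moderate cost, and a 16-fold higher number from compound 2 to compound 4 (1.20 log units; beyond the scatter) puts the same group clearly behind 3-hydroxyazetidin-1-yl. Even so, a 10-fold lower number from compound 1 to compound 4 (1.00 log units; beyond the scatter) shows that it still outperforms ((1H-imidazol-2-yl)carbonyl)amino, so a low number here does not require a hydrogen-bond donor on this chain. No supporting measurement bears on this result. Still open, from the compounds shown here alone, is which part of the change carries the step: acetylamino would separate the methyl on the amide nitrogen from the loss of the (methylamino)methyl group. A primary amine on the same chain carbon would test whether the carbonyl is needed at all.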